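The compounds below may be only part of what the source reports. "The series", "measured", "known", "first", "only" and "open" are said of these compounds alone.

Measured compounds in the series:

compound 1, `COC(=O)C(Cc1cccc(C(=N)N)c1)C(/C=C/c1ccccc1)NC(=O)c1ccc(-c2ccccc2OC)cc1` — in an assay on isolated protein (Oryctolagus cuniculus) for inhibition of Trypsin (Homo sapiens) (a lower number here means a stronger inhibitor, a higher number a weaker inhibitor), compound 1 gives 1800 nM
compound 2, `COC(=O)C(Cc1cccc(C(=N)N)c1)C(/C=C/c1ccccc1)NC(=O)c1ccc(-c2cccc(OC)c2)cc1` — in this assay compound 2 gives 2200 nM

For the measured compounds named here, compound 2 stands next to compound 1 and the two numbers lie within the usual scatter of each other; the one measured step, a 1.2-fold higher number from compound 1 to compound 2 (0.09 log units; within the scatter), does not rise above it.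

Compound 3, `COC(=O)C(Cc1cccc(C(=N)N)c1)C(/C=C/c1ccccc1)NC(=O)c1ccc(-c2ccc(OC)cc2)cc1`, is not yet measured. It differs from compound 2 in that (4-methoxyphenyl in place of 3-methoxyphenyl on an aromatic carbon). Going by the values given here, the only step that bears on this is the earlier walk of the same methoxy group around the terminal ring, a 1.2-fold higher number from compound 1 to compound 2 (0.09 log units; within the scatter), which left the number essentially unchanged. A further move of the methoxy group on that ring is therefore expected to give no step beyond the scatter in this assay, in either direction.

For compound 3 the estimate in this assay is 2000 nM, with a range from 800 nM to 5000 nM. This estimate means an expected step of a 1.1-fold lower number from compound 2 to compound 3 (0.04 log units; within the scatter).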

Compound 3, half-maximal inhibitory concentration: 2900 nM
For compound 3 the middle estimate is 1.5-fold (0.16 log units) below the measured one; measured number inside the range.
By their numbers in this assay, from the lowest: compounds 1, 2 and 3 (each within the scatter of the next).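

With the 4-methoxyphenyl compound added, all three placings of the methoxy group on the six-membered aromatic ring are covered, where the earlier pair covered only two. In this assay neither new comparison rises above the scatter: the one is a 1.3-fold higher number from compound 2 to compound 3 (0.12 log units; within the scatter), the other 1.6-fold higher number from compound 1 to compound 3 (0.21 log units; within the scatter), so among compounds 1, 2 and 3 the placing of the methoxy group does not separate the inhibitors. No measurement bears on why the numbers stay so close.

From the compounds shown here alone, the three compounds keep the methoxy group throughout, so what a hydroxyl, an amine or a carboxylic acid would do on the same ring remains open. Also open, going by these compounds, is whether this flat response to the placing would persist with a longer chain, such as ethoxy or propoxy, in place of methoxy.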